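Cytotoxicity notes on an enone series, one change tracked

This account rests on a few compounds, and the source may have more. Where it says the series, first, only, none or still open, it means among the compounds named here.

Measured compounds:
compound 1, `CN1C/C(=C\c2cccnc2)C(=O)/C(=C/c2ccccc2F)C1`, 15900 nM
compound 2, `CN1C/C(=C\c2cccnc2)C(=O)/C(=C/c2ccccc2C(F)(F)F)C1`, 14100 nM
compound 3, `O=C1/C(=C/c2ccncc2)CN(S(=O)(=O)c2ccc(C(F)(F)F)cc2)C/C1=C\c1ccccc1F`, 18600 nM

In an ADME assay on L02 cells (Homo sapiens) for cytotoxicity, read by MTT assay, with a stated time of 24 h (on this read-out higher numbers stand for weaker inhibition and lower numbers for stronger inhibition), the three measured compounds sit close together. The step of a 1.1-fold higher number from compound 2 to compound 1 (0.05 log units; within the scatter) is the change (fluoro in place of trifluoromethyl on an aromatic carbon). The difference between the core of compound 2 and the core of compound 3 is not broken down here. Compound 4, `O=C1/C(=C/c2ccncc2)CN(S(=O)(=O)c2ccc(F)cc2)C/C1=C\c1ccccc1F`, is not yet measured; it comes from compound 3 by fluoro in place of trifluoromethyl on an aromatic carbon, the same kind of change as from compound 2 to compound 1, but with the place read as para to a large group rather than ortho to a large group. Because the step of a 1.1-fold higher number from compound 2 to compound 1 (0.05 log units; within the scatter) stayed within the scatter, the expected step of a 1.1-fold higher number from compound 3 to compound 4 (0.03 log units; within the scatter) is small as well, resting on that single earlier pair. For compound 4 in this assay the estimate is 20000 nM, expected between 10000 nM and 40000 nM.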

Compound 4, half-maximal inhibitory concentration: 15600 nM
Compound 4: middle estimate off by 1.3-fold (0.11 log units), on the high side; the range from low to high includes it.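

In this assay, fluoro in place of trifluoromethyl on the core of compound 3 gives a 1.2-fold lower number from compound 3 to compound 4 (0.08 log units; within the scatter). Set beside the earlier pair, the change carries across the two cores without a detectable difference: the same change on two cores in this assay, a 1.1-fold higher number (0.05 log units; within the scatter) from compound 2 to compound 1 and a 1.2-fold lower number (0.08 log units; within the scatter) from compound 3 to compound 4, 1.3-fold (0.13 log units) apart, within the scatter of two such steps. This supports only a small step on these two cores, with the place differing between the pairs; it gives no direction for the change and does not show that the step would stay small on any other core.

Open, as far as these compounds go, is whether an amine or a carboxylic acid at this place would give a step beyond the scatter. Also open, from the compounds shown here alone, is whether the same small step would appear in a read-out other than this cell assay.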